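Selenocyanate and diselenide carbamates: cytotoxicity on colon cells

The source may hold more compounds than are shown below. What is called first, only, known or untested is meant among the compounds shown, and "the series" means these compounds.

Measured so far:
compound 1 `CCCOC(=O)Nc1ccc([Se]C#N)cc1` with 51900 nM
compound 2 `Cc1ccc(OC(=O)Nc2ccc([Se][Se]c3ccc(NC(=O)Oc4ccc(C)cc4)cc3)cc2)cc1` with 39400 nM
compound 3 `CCCCOC(=O)Nc1ccc([Se][Se]c2ccc(NC(=O)OCCCC)cc2)cc1` with 55000 nM

In a functional assay on HT-29 cells (Homo sapiens) for cytotoxicity, read by MTT assay, with a stated time of 72 h (a lower number here means a stronger inhibitor of growth, a higher number a weaker inhibitor of growth), the three measured compounds give numbers of the same order. Compound 1 stands second highest of the three; its nearest neighbour is compound 3, and its furthest is compound 2, both within the scatter of this assay, so no order among the three can be drawn. Compounds 2 and 3 share the diselenide core and differ in the carbamate ester group; in this assay compound 2 gives 39400 nM and compound 3 gives 55000 nM.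

Compound 4 `N#C[Se]c1ccc(NC(=O)Oc2ccccc2)cc1` keeps the core of compound 1 and differs only in the carbamate ester: phenyl in place of propyl on an oxygen next to a carbonyl group. Among the compounds with values here, no step between measured compounds corresponds to this change. The values of compounds 2 and 3 suggest that an aryl carbamate and an alkyl carbamate on a related core end up close to each other. The expected step of a 1.1-fold lower number from compound 1 to compound 4 (0.03 log units; within the scatter) is therefore none beyond the scatter, in either direction. Compound 4 is estimated at 48000 nM in this assay, within a range of 22000 nM to 105000 nM.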

Compound 4, concentration for total growth inhibition: 41700 nM
Beside the measured number, compound 4's estimate is 1.2-fold (0.06 log units) above it; the range from low to high includes it.
By their numbers in this assay, from the lowest: compounds 2, 4, 1 and 3 (each within the scatter of the next).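

In this assay, within the data shown here, the change of phenyl in place of propyl on an oxygen next to a carbonyl group gives a 1.2-fold lower number from compound 1 to compound 4 (0.10 log units; within the scatter) and is the first comparison between compounds that differ in one place. Among these compounds, on the core of compound 1, this position therefore holds either a propyl or a phenyl group with no difference that the assay can separate, which the earlier compounds, differing in more than one place, could not show. No measurement at hand offers an explanation for this result.

Still open, as far as these compounds go, is whether a longer chain, a benzyl group or an amine on the ester would move the number beyond the scatter. Also open, from the compounds shown here alone, is how a selenocyanate and a diselenide carrying the same ester compare in this assay.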